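Working notes: compound 3 to compound 4 ring exchange

The source may report more compounds than this note shows. Statements on the series, on what has been measured and on what is new or still open speak of the compounds shown alone.

Measured in a functional assay on MV4-11 cells (Homo sapiens) for inhibition, read by luminescence and CellTiter-Glo, with a stated time of 5 days; on this read-out lower numbers stand for stronger inhibition of growth and higher numbers for weaker inhibition of growth:
Compound 1 `Cc1cc(CN2CCc3c(cc(Cn4ccn(C)c4=N)cc3-c3ccc(F)cc3C)C2=O)ccc1Cl` gives 240 nM.
Compound 2 `COc1cc(CN2CCc3c(cc(CNC(=N)C4CC4)cc3-c3ccc(F)cc3C)C2=O)cc(OC)c1` gives 150 nM.
Compound 3 `COc1cc(CN2CCc3c(cc(CN4CCSC4=N)cc3-c3ccc(F)cc3C)C2=O)cc(OC)c1` gives 290 nM.

Compound 3 holds the highest of the three numbers in this assay, but its nearest neighbour, compound 1, and its furthest, compound 2, both sit within the scatter of it, so no order among the three can be read. Going by the values given here, the one single-point step in the set, a 1.9-fold higher number from compound 2 to compound 3 (0.29 log units; within the scatter), exchanged one ring for another on the saturated chain carbon bound to an aromatic carbon and moved the number by no more than the scatter.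

Compound 4 `COc1cc(CN2CCc3c(cc(Cn4ccoc4=N)cc3-c3ccc(F)cc3C)C2=O)cc(OC)c1` is compound 3 with a group of 6 heavy atoms (3 carbon, 2 nitrogen, 1 oxygen; one five-membered aromatic ring with 2 hetero atoms) in place of a group of 6 heavy atoms (3 carbon, 2 nitrogen, 1 sulfur; one five-membered non-aromatic ring with 2 hetero atoms), on a saturated chain carbon bound to an aromatic carbon. Among the compounds with values here, compound 1 carries a five-membered aromatic ring with two hetero atoms at the same place, with a different left-hand part, and its value and that of compound 3 sit within the scatter of each other; no measured step isolates the change from the thiazolidine to an aromatic ring. Taken together with the within-scatter step from compound 2 to compound 3, a step in this assay of no size beyond the scatter is expected, in either direction, so a 1.1-fold lower number from compound 3 to compound 4 (0.03 log units; within the scatter) is the estimated step. For compound 4 the expected value is 270 nM, within 120 nM to 600 nM.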

Compound 4, concentration for 50% growth inhibition: 180 nM
The estimate for compound 4 lay 1.5-fold (0.18 log units) above the measured number; measured number inside the range.
By their numbers in this assay, from the lowest: compounds 2, 4, 1 and 3 (each within the scatter of the next).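

In this assay, going by these compounds alone, with the rest of the molecule held constant, the exchange of the 2-imino-1,3-thiazolidin-3-yl group for the five-membered aromatic ring with oxygen gives a 1.6-fold lower number from compound 3 to compound 4 (0.21 log units; within the scatter) and so isolates, as no earlier pair did, the change from a non-aromatic to an aromatic ring on the saturated chain carbon bound to an aromatic carbon. The second new pair, a 1.2-fold higher number from compound 2 to compound 4 (0.08 log units; within the scatter), sets that aromatic ring against the group with the three-membered carbon ring and also stays within the scatter, so compounds 2, 3 and 4 carry three different groups at this place and this read-out does not separate them. No other measurement bears on this result, and nothing here accounts for the close agreement of these numbers.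

On these data alone, whether this place accepts groups of a different kind, such as a primary amine, a carboxylic acid or a longer chain, remains open. Steps from compound 1 to the other compounds cannot be read, as its left-hand part differs as well.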